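Clearance notes: difluoromethoxy in place of methyl

The source may report more compounds than this note shows. Statements on the series, on what has been measured and on what is new or still open speak of the compounds shown alone.

Compound 1 `COc1cccc2nnn(CC(=O)N[C@@H](C)c3ccc(C)cc3)c(=O)c12` gives 48 mL/min/kg in an ADME assay on microsomes from liver (Homo sapiens) for metabolic stability; a lower number here means slower removal, a higher number faster removal of the compound
Compound 2 `Cc1ccc([C@H](C)NC(=O)Cn2nnc3ccc(C)cc3c2=O)cc1` gives 179 mL/min/kg in this assay

Compound 1 holds the lower of the two numbers, and its gap to compound 2 lies beyond the usual scatter. Compound 3 `COc1cccc2nnn(CC(=O)N[C@@H](C)c3ccc(OC(F)F)cc3)c(=O)c12` departs from compound 1 in one place (difluoromethoxy in place of methyl on an aromatic carbon), with difluoromethoxy in place of methyl on an aromatic carbon of a six-membered aromatic ring of carbon only, para to a large group.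

Among the compounds with values here, no measured pair shows this change on its own, so there is no step to carry over. In this assay no step beyond the scatter is expected, in either direction. The range is still kept wide, since compound 1 (48 mL/min/kg) and compound 2 (179 mL/min/kg) show that numbers in this series can lie well apart. The estimated step is a 1.1-fold lower number from compound 1 to compound 3 (0.04 log units; within the scatter) and would stay within the scatter. For compound 3 the expected clearance is 44 mL/min/kg (estimated range 22 mL/min/kg to 90 mL/min/kg).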

Compound 3, clearance in the Homo sapiens assay: < 9.9 mL/min/kg
Compound 3: a limit, no number; the forecaster's own chance of this, stated with the estimate: 3%; middle value at least 4.4-fold (0.64 log units) away from the limit.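

Within the data shown here, at the aromatic carbon para to a large group, difluoromethoxy in place of methyl is the first change that can be read on its own, and in the Homo sapiens assay the change amounts to an at least 4.8-fold lower number from compound 1 to compound 3 (0.68 log units; beyond the scatter). In the Homo sapiens assay compound 3 gives < 9.9 mL/min/kg, a limit of that assay and not a number: the limit of < 9.9 mL/min/kg in the Homo sapiens assay, at which 1 of the 3 values shown sits. In a physicochemical assay for solubility, read by HPLC, in phosphate buffer, with a stated time of 16 h, at pH 6.8 (a lower number here means a less soluble compound, a higher number a more soluble compound), compound 1 gives 9300 nM and compound 3 gives 9600 nM. In the physicochemical assay the same change gives a 1.0-fold higher number from compound 1 to compound 3 (0.01 log units; within the scatter), so in these two compounds the step in clearance comes with no step beyond the scatter in solubility.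

The compounds shown leave open whether this step is particular to difluoromethoxy or would also appear with another group at this place, such as trifluoromethoxy, chlorine or a nitrile. They also leave open whether the same change carries over to the core of compound 2. In the Homo sapiens assay compound 2 gives 179 mL/min/kg. From the compounds shown here alone, how far the clearance of compound 3 lies under its limit also stays open.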